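The compounds below may be only part of what the source reports. "The series", "measured", "known", "first", "only" and "open" are said of these compounds alone.

The compounds measured so far:
compound 1, `COc1cc(O)cc(O)c1C(=O)/C=C/c1ccc(O)cc1`, > 50000 nM;
compound 2, `COc1cc(/C=C/C(=O)c2c(O)cc(O)cc2OC)ccc1O`, > 50000 nM;
compound 3, `COc1cc(/C=C/C(=O)c2c(O)cc(O)cc2OC)cc(OC)c1`, 34000 nM.

All three were tested in a functional assay on A549 cells (Homo sapiens) for inhibition, read by MTT assay, with a stated time of 72 h; a lower number here means a stronger inhibitor, a higher number a weaker inhibitor. For compound 1 the value > 50000 nM is a limit of the assay, not a number. For compound 2 the value > 50000 nM is likewise a limit. Within the data shown here, compound 3 is the only one with a measured number, 34000 nM in this assay; the other two sit at the limit of > 50000 nM in this assay, at which 2 of the 3 values shown sit.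

Compound 2 arises from compound 1 by methoxy in place of hydrogen on an aromatic carbon. The step that the two limits leave unreadable from compound 1 to compound 2 cannot be read in size, as both ends are limits. How the core of compound 3 differs from that of compound 1 is not broken down here.

Compound 4, `COc1cc(/C=C/C(=O)c2c(O)cc(O)cc2OC)cc(OC)c1OC`, has not yet been measured. It arises from compound 3 by methoxy in place of hydrogen on an aromatic carbon, the same kind of change as from compound 1 to compound 2, though the surroundings differ: here the new group sits ortho to two methoxy groups and para to a large group, whereas in compound 2 it sits ortho to a hydroxy group and meta to a large group. Among the measured compounds shown here, since the only earlier instance of this change is unreadable, the expectation for compound 4 rests mainly on compound 3 at 34000 nM, and the step of a 1.7-fold lower number from compound 3 to compound 4 (0.23 log units; within the scatter) is expected to be modest. Compound 4 is therefore estimated at 20000 nM in this assay, with a range from 5000 nM to 60000 nM.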

Compound 4, half-maximal inhibitory concentration: 28400 nM
Beside the measured number, compound 4's estimate is 1.4-fold (0.15 log units) below it, and the stated range covers the measured number.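

In this assay, methoxy in place of hydrogen on an aromatic carbon gives a 1.2-fold lower number from compound 3 to compound 4 (0.08 log units; within the scatter), so on the core of compound 3 this change has no effect that can be told apart from the usual differences between repeated measurements. This is the only instance of the change whose size can be read, so it does not show whether the result carries over to another core, and a larger effect on the core of compound 1 is neither shown nor ruled out. The same change from compound 1 to compound 2 cannot be read, as the values of both compounds are limits of the assay and not numbers: the limit of > 50000 nM in this assay, at which 2 of the 4 values shown sit.

The compounds shown leave open what a group other than methoxy would do on this ring, for example an amine, a carboxylic acid or a longer chain such as ethoxy. They also leave open whether this change would give a readable step on any core other than that of compound 3.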